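Adding a Hydroxy Group to the Core of Compound 1

A few compounds are considered here, and "the series" means these few. Any claim that something is new, unique, unknown or untested is made for them only; others in the source may bear on it.

Compound 1 `COc1ccc(-c2cc(=O)c3cc(N)ccc3o2)cc1` in an ADME assay on THP-1 cells (Homo sapiens) for cytotoxicity, read by flow cytometry and propidium iodide staining, with a stated time of 72 h (on this read-out lower numbers stand for stronger inhibition and higher numbers for weaker inhibition), gives 124000 nM, the highest of the two numbers measured. Compound 2 `Nc1ccc2oc(-c3ccc(C(F)(F)F)cc3)cc(=O)c2c1` in this assay gives 1900 nM. Among the measured compounds shown here, the only measured step is a 65-fold lower number from compound 1 to compound 2 (1.81 log units; beyond the scatter). Compound 3 `COc1ccc(-c2oc3ccc(N)cc3c(=O)c2O)cc1` differs from compound 1 by hydroxy in place of hydrogen on an aromatic carbon. For the measured compounds named here, that single measured step concerns a change at a different place, so it does not bear on this one, and no measured step speaks to adding a hydroxy here. The expectation is therefore a step of a 1.2-fold lower number from compound 1 to compound 3 (0.09 log units; within the scatter), nothing beyond the scatter. Compound 3 is expected to give 100000 nM, between 30000 nM and 300000 nM.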

Compound 3, half-maximal inhibitory concentration: 29000 nM
Estimate against measurement, compound 3: 3.4-fold (0.54 log units) above; the measured number lies below the stated range.
By their numbers in this assay, from the lowest: compound 2; then compound 3; then compound 1.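

Hydroxy in place of hydrogen on this aromatic carbon of the core does change the result: this assay shows a 4.3-fold lower number from compound 1 to compound 3 (0.63 log units; beyond the scatter). The position, two atoms from the ring oxygen, therefore responds to this small change, and the lower number stands for stronger inhibition. Nothing measured here explains the step.

As far as these compounds go, it remains open whether a fluorine atom or a carboxylic acid on this carbon would give a step of similar size. From the compounds shown here alone, it is also open whether hydroxy here would lower the number of compound 2 as well.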